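Sulfonic acid in place of a carboxylic acid on the sulfonamide

This account rests on a few compounds, and the source may have more. Where it says the series, first, only, none or still open, it means among the compounds named here.

Measured compounds:
Compound 1 `CN1Cc2c(Cl)cc(Cl)cc2[C@@H](c2cccc(NC(=O)[C@H](O)[C@@H](O)[C@H](O)[C@H](O)CO)c2)C1`: 7940 nM
Compound 2 `CN1Cc2c(Cl)cc(Cl)cc2C(c2cccc(S(=O)(=O)NCC(=O)O)c2)C1`: 100 nM

Of the compounds shown here, two sharing the same dichlorinated core have been measured in an assay on cells (Kidney epithelial cell, kidney) for inhibition of sodium/hydrogen exchanger 3 (Rattus norvegicus), read by fluorescence, in the presence of a further agent that is not named here; a lower number here means a stronger inhibitor, a higher number a weaker inhibitor. Compound 1 carries a polyhydroxylated amide on the pendant ring and gives 7940 nM in this assay. Compound 2 carries instead a sulfonamide bearing a carboxymethyl group, and in this assay compound 2 gives 100 nM, the lowest of the two numbers and a gap to compound 1 that lies well beyond the scatter of the assay.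

Compound 3 `CN1Cc2c(Cl)cc(Cl)cc2C(c2cccc(S(=O)(=O)NCCCS(=O)(=O)O)c2)C1` has not been measured. It differs from compound 2 only in the acid terminus of the chain on the sulfonamide nitrogen: 2-sulfoethyl in place of carboxy on a saturated chain carbon bound to a sulfonamide nitrogen. Within the data shown here, no directly comparable pair of measured compounds exists for this change, so the direction cannot be read from the data at hand. Since an acidic terminus is kept, the step from compound 2 to compound 3 is expected to be small, a 1.5-fold higher number from compound 2 to compound 3 (0.18 log units; within the scatter), probably within the scatter of the assay. Compound 3 is therefore estimated at 150 nM in this assay, with a plausible range from 40 nM to 600 nM.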

Compound 3, half-maximal inhibitory concentration: 50.1 nM
Compound 3: the middle estimate sits 3.0-fold (0.48 log units) above what was measured, within the range that was stated.
By their numbers in this assay, from the lowest: compounds 3 and 2 (each within the scatter of the next); then compound 1.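

In this assay, 2-sulfoethyl in place of carboxy on a saturated chain carbon bound to a sulfonamide nitrogen gives a 2.0-fold lower number from compound 2 to compound 3 (0.30 log units; within the scatter), so at this position the carboxylic acid terminus can give way to a sulfonic acid terminus without a step that stands out from the scatter. Cut one bond further out, the same difference reads carboxymethyl to 3-sulfopropyl, so the end group and the length of the chain change together, and this single step shows only that the two changes taken jointly leave the number within the scatter. Nothing shown here gives a measured reason for this result.

Going by these compounds, what remains open is how far each change counts alone: a carboxylic acid on the longer chain, or a sulfonic acid on the shorter one, would separate the end group from the chain length. On these data alone, how an amine or a simple alcohol at the end of this chain would read in this assay also stays open, as does the effect of a chain longer than 3-sulfopropyl.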